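The compounds below may be only part of what the source reports. "The series", "measured", "known", "first", "only" and "open" are said of these compounds alone.

Measured so far in a functional assay on cells (Hepatocyte, Mus musculus), with a stated time of 6 h; on this read-out lower numbers stand for an effect already at smaller amounts and higher numbers for an effect only at larger amounts of compound:

- compound 1 `Cc1cccc(S(=O)(=O)NC(=O)Nc2cc(Br)cc3[nH]ncc23)c1` gives 13000 nM
- compound 2 `COCCc1sc(S(=O)(=O)NC(=O)Nc2cc(OC)cc(N)n2)cc1C` gives 97000 nM

Compound 2 holds the higher of the two numbers, and its gap to compound 1 is beyond the scatter. The two compounds differ in more than one place, so their values show only that gap and do not isolate any single change.

Compound 3 `COCCc1sc(S(=O)(=O)NC(=O)Nc2cc(C(F)(F)F)cc(N)n2)cc1C` has not yet been measured. It differs from compound 2 in one place, with trifluoromethyl in place of methoxy on an aromatic carbon, opposite the ring nitrogen and meta to an amino group. Going by the values given here, no measured pair shows this exchange, so any expectation for it is weakly supported.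

Among the compounds with values here, the one guide is that compound 2, at 97000 nM, sits at the top of the measured range, which leaves more room for a lower number than a higher one. A small step toward a lower number, close to the edge of the scatter, is therefore expected. The estimated step is a 2.2-fold lower number from compound 2 to compound 3 (0.33 log units; beyond the scatter) in this assay. For compound 3 the expected value is 45000 nM, with an estimated range of 12000 nM to 150000 nM.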

Compound 3, half-maximal effective concentration: 8000 nM
Estimate against measurement, compound 3: 5.6-fold (0.75 log units) above; measured number outside the range, below it.
By their numbers in this assay, from the lowest: compounds 3 and 1 (each within the scatter of the next); then compound 2.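

In this assay, the aromatic carbon opposite the ring nitrogen and meta to an amino group responds strongly to a single exchange: trifluoromethyl in place of methoxy gives a 12-fold lower number from compound 2 to compound 3 (1.08 log units; beyond the scatter) as a large step, beyond the scatter. Going by these compounds alone, this is the first step that isolates one change, whereas compound 1 and compound 2 differ in more than one place and show only a gap. No measurement is available to explain the size or direction of this step.

From the compounds shown here alone, a single exchange cannot separate the departure of methoxy from the arrival of trifluoromethyl, so it remains open whether other groups at this position, such as chlorine, methyl or nitrile, would give a similar step. Going by these compounds, it also remains open whether the step would persist if the amino group were replaced, for instance by a hydroxyl group, or if the same exchange were carried out on a different core.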